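The source may report more compounds than this note shows. Statements on the series, on what has been measured and on what is new or still open speak of the compounds shown alone.

Of the compounds shown here, two of a shared core have numbers so far. Compound 1, `Cc1cc(NCCN2CCN(C)CC2)nc2ccc(NC(=O)c3ccc(Cl)c(Cl)c3)cc12`, is measured in a functional assay on MCF7 cells (Homo sapiens) for antiproliferative activity, read by MTT assay, with a stated time of 72 h (a lower number here means a stronger inhibitor, a higher number a weaker inhibitor), where compound 1 gives 1700 nM. Compound 2, `CCN1CCN(c2cc(C)c3cc(NC(=O)c4ccc(OC)cc4)ccc3n2)CC1`, is tested in the same way; in this assay compound 2 gives 7690 nM. Compound 2 stands at the higher of the two numbers, so it is the weaker inhibitor of the pair, and the gap to compound 1 lies beyond the usual scatter. The two differ in more than one place, so no single change explains that gap.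

Compound 3, `CCN1CCN(c2cc(C)c3cc(NC(=O)c4ccc(F)cc4)ccc3n2)CC1`, has not yet been measured. It differs from compound 2 in one place only: fluoro in place of methoxy on an aromatic carbon. Going by the values given here, no pair of measured compounds differs by this change alone, so nothing measured here tells how large a shift to expect. The shift from this change is expected to be a 1.0-fold lower number from compound 2 to compound 3 (0.01 log units; within the scatter), which is no more than the scatter of repeated runs. Compound 3 is therefore expected to give 7500 nM in this assay, within a range from 2500 nM to 22000 nM.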

Compound 3, half-maximal inhibitory concentration: 4030 nM
Beside the measured number, compound 3's estimate is 1.9-fold (0.27 log units) above it, and the stated range covers the measured number.
By their numbers in this assay, from the lowest: compound 1; then compounds 3 and 2 (each within the scatter of the next).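

Going by these compounds alone, this is the first pair in which only one place changes: on an aromatic carbon of the six-membered ring, para to a large group, fluoro takes the place of methoxy, and this assay shows a 1.9-fold lower number from compound 2 to compound 3 (0.28 log units; within the scatter). With the rest of the molecule held fixed, the two groups therefore cannot be told apart in this assay, even though methoxy has two heavy atoms and one hydrogen-bond acceptor, while fluoro has one heavy atom and no such acceptor. Nothing available here gives an explanation for this result.

Within the data shown here, this one pair shows only two groups at this position on a single version of the shared core, so it cannot show whether an amine, a carboxylic acid or a longer chain such as butoxy would leave the number just as little changed. Compound 1 differs from compound 2 and from compound 3 in more than one place, so the compounds shown also leave open which of those differences matters in this assay.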